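Formyl-for-methyl exchange on a two-membered series

A few compounds are considered here, and "the series" means these few. Any claim that something is new, unique, unknown or untested is made for them only; others in the source may bear on it.

Two compounds of the shared core have numbers in a functional assay on CAKI-1 cells (Homo sapiens) for inhibition, read by sulforhodamine B assay, with a stated time of 48 h, tested at 10 uM; on this read-out higher numbers stand for more inhibition at the one concentration tested (going by the name of the read-out) and lower numbers for less inhibition. Compound 1 `O=Cc1ccc(-c2cn3ccnc3c(-c3ccc4ncn(C5CCCCC5)c4c3)n2)cc1` gives 36.6% and compound 2 `Cc1cccc(-c2cn3ccnc3c(-c3ccc4ncn(Cc5ccccc5)c4c3)n2)c1` gives 24.8%. Compound 2 stands lowest of the two; its nearest neighbour is compound 1, whose number is higher by a margin that lies beyond the usual scatter. Within the data shown here, since compound 1 and compound 2 differ in two places at once, no single step between measured compounds can be read off.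

Compound 3 `O=Cc1ccc(-c2cn3ccnc3c(-c3ccc4ncn(Cc5ccccc5)c4c3)n2)cc1` has not been measured. It differs from compound 2 at one place only: 4-formylphenyl in place of 3-methylphenyl on an aromatic carbon. Compound 3 thus carries the same 4-formylphenyl group as compound 1, and the benzyl group of compound 2. With no counted step for this exchange, the expectation rests only on the two numbers shown, which place compound 3 between them. The step from compound 2 is expected to be modest and upward, a number 6.2 percentage points higher from compound 2 to compound 3 (within the scatter), though a change within the scatter cannot be excluded. Compound 3 is estimated to give 31% in this assay, with a range from 17% to 45%.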

Compound 3, a percentage reported as inhibition, at one concentration (the size of the read-out at that concentration, not a potency): 36.6%
Beside the measured number, compound 3's estimate is 5.6 percentage points below it; the measured number falls inside the stated range.
By their numbers in this assay, from the lowest: compound 2; then compounds 1 and 3 (each within the scatter of the next).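

Working notes on the series: in this assay the exchange of 3-methylphenyl for 4-formylphenyl, on the aromatic carbon next to the ring nitrogen and with benzyl held on the aromatic nitrogen, gives a number 11.8 percentage points higher from compound 2 to compound 3 (beyond the scatter) and is the first single-place reading at this position, where the earlier pair differed in two places at once. With 4-formylphenyl held, benzyl in place of cyclohexyl on the aromatic nitrogen gives no change at the digits printed from compound 1 to compound 3 (within the scatter) and so this read-out does not separate these two groups in this setting. Nothing at hand speaks to the reason for either step.

As far as these compounds go, the step from 3-methylphenyl to 4-formylphenyl changes both the group and its place on the phenyl ring, so it remains open which of the two carries the step, a question that 4-methylphenyl and 3-formylphenyl at this carbon would address. Also open, from the compounds shown here alone, are how a hydroxymethyl group, a carboxylic acid or an amine in place of the formyl group would read, and whether benzyl and cyclohexyl still match when 3-methylphenyl occupies this carbon.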